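Replacing the 2-(phenylsulfonyl)ethenyl group of compound 1

The source may hold more compounds than are shown below. What is called first, only, known or untested is meant among the compounds shown, and "the series" means these compounds.

Measured so far in a functional assay on MKN-45 cells (Homo sapiens) for antiproliferative activity, read by MTT assay, with a stated time of 72 h (a lower number here means a stronger inhibitor, a higher number a weaker inhibitor), are two compounds:
- compound 1 `COc1cc2c(Oc3ccc(NC(=O)/C=C/S(=O)(=O)c4ccccc4)cc3F)ccnc2cc1OCCCN1CCN(C)CC1` gives 450 nM
- compound 2 `COc1cc2c(Oc3ccc(/C=N/NC(=O)Nc4ccccc4F)cc3F)ccnc2cc1OCCCN1CCCCC1` gives 16 nM

Compound 1 holds the higher of these two numbers, which makes it the weaker inhibitor, and its gap to compound 2 lies beyond the usual scatter of repeated measurements.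

Compound 3 `COc1cc2c(Oc3ccc(NC(=O)Nc4nc5c(C)ccc(C)c5s4)cc3F)ccnc2cc1OCCCN1CCN(C)CC1` is still unmeasured. It keeps the core of compound 1 and differs in one place, on a carbonyl carbon whose other neighbour is an amide-type nitrogen. There, (4,7-dimethyl-1,3-benzothiazol-2-yl)amino stands in place of 2-(phenylsulfonyl)ethenyl (4,7-dimethyl-1,3-benzothiazol-2-yl)amino in place of 2-(phenylsulfonyl)ethenyl on a carbonyl carbon and the rest of the molecule stays the same.

Going by the values given here, no measured pair shows a change of this kind, so the size of the step has to be judged rather than read off. Compound 2, at 16 nM in this assay, shows that much lower numbers occur among these molecules. It differs from compound 1 in more than one place and is only a loose guide. An estimated step of a 5.6-fold lower number from compound 1 to compound 3 (0.75 log units; beyond the scatter) is expected, toward a lower number and beyond the scatter. For compound 3 the expected value is 80 nM within an estimated range of 20 nM to 320 nM in this test.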

Compound 3, half-maximal inhibitory concentration: 60 nM
Beside the measured number, compound 3's estimate is 1.3-fold (0.12 log units) above it; measured number inside the range.
By their numbers in this assay, from the lowest: compound 2; then compound 3; then compound 1.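

At the carbonyl carbon whose other neighbour is an amide-type nitrogen, this assay now gives a direct reading of one change: putting (4,7-dimethyl-1,3-benzothiazol-2-yl)amino in place of 2-(phenylsulfonyl)ethenyl gives a 7.5-fold lower number from compound 1 to compound 3 (0.88 log units; beyond the scatter) and leaves the rest of the molecule as it was. This place is therefore not tied to the 2-(phenylsulfonyl)ethenyl group, since a group with a five-membered and a six-membered aromatic ring, and with a hydrogen-bond donor that the old group lacks, goes with a lower number here. The swap alters all of these features at once and also removes the double bonds outside aromatic rings, and no measurement shown explains the shift in the number.

On these data alone, whether the two methyl groups contribute stays open, and a 1,3-benzothiazol-2-ylamino group without them would test that directly. A plain phenylamino group at the same place would show whether a single six-membered aromatic ring carrying the amino link can give a similar number.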